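The compounds below may be only part of what the source reports. "The series", "measured", "known", "first", "only" and "open" are said of these compounds alone.

Working notes on the series. Compound 1 `N=C(NCCCc1c[nH]cn1)NC(=O)CC(c1ccccc1)c1ccccc1` gives 85% in a functional assay on cardiac atrium for agonist activity at histamine H2 receptor (Cavia porcellus); on this read-out higher numbers stand for larger maximal responses and lower numbers for smaller maximal responses. Among the compounds with values here, compound 2 `N=C(NCCCc1c[nH]cn1)NC(=O)CC(c1ccccc1)c1nccs1` gives 100%; the only measured step is a number 15 percentage points higher from compound 1 to compound 2 (beyond the scatter). Compound 3 `CC(CC(=O)NC(=N)NCCCc1c[nH]cn1)c1cccs1` gives 99%, the second highest of the three numbers, within the scatter of compound 2 and beyond the scatter above compound 1. Compound 4 `CC(CC(=O)NC(=N)NCCCc1c[nH]cn1)c1nccs1` is not yet measured and differs from compound 3 by 1,3-thiazol-2-yl in place of thiophen-2-yl on a saturated chain carbon bound to two saturated chain carbons. Within the data shown here, the one measured step also brings in a 1,3-thiazol-2-yl and was a number 15 percentage points higher from compound 1 to compound 2 (beyond the scatter), though there phenyl left rather than thiophen-2-yl. Since compound 3 already sits near the top of the range with 99%, no step beyond the scatter is expected. Compound 4 is expected at 100%, between 90% and 108%. This corresponds to an expected step of a number 1 percentage points higher from compound 3 to compound 4 (within the scatter).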

Compound 4, largest response reached (Emax), in percent of the reference or control that the assay uses: 91%
For compound 4 the middle estimate is 9 percentage points above the measured one, and the stated range covers the measured number.
By their numbers in this assay, from the lowest: compounds 1, 4, 3 and 2 (each within the scatter of the next, the first and the last beyond it).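

In this assay, the change on a saturated chain carbon bound to two saturated chain carbons gives a number 8 percentage points lower from compound 3 to compound 4 (within the scatter), so 1,3-thiazol-2-yl in place of thiophen-2-yl leaves the maximal response within the scatter here. Methyl in place of phenyl, on a saturated chain carbon bound to an aromatic carbon and a saturated chain carbon, gives a number 9 percentage points lower from compound 2 to compound 4 (within the scatter), so this swap also stays within the scatter. Nothing available bears on a cause for either step. From the compounds shown here alone, what an ethyl group or a primary amine in place of that methyl would give in this assay stays open.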